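The source may report more compounds than this note shows. Statements on the series, on what has been measured and on what is new or still open speak of the compounds shown alone.

Measured so far:
- compound 1, `O=C(N[C@H]1COC1=O)c1ccc(C(=O)Oc2ccccc2)cc1`, 300 nM
- compound 2, `O=C(CCc1ccccc1)N[C@@H]1COC1=O`, 6000 nM

Both compounds were tested in an assay on HEK293 cells for inhibition of N-acylethanolamine-hydrolyzing acid amidase (Rattus norvegicus), with a stated time of 30 min; on this read-out higher numbers stand for weaker inhibition and lower numbers for stronger inhibition. Of the two numbers, compound 2 gives the highest, 6000 nM, which on this read-out means the weaker inhibition; compound 1 gives a clearly lower number, and the gap between them lies beyond the usual scatter of repeated measurements. Compound 2 is therefore the weaker of the two inhibitors, not the stronger.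

The next compound, compound 3 with the structure `O=C(CCc1ccccc1)NC1CCC1=O`, keeps the whole of compound 2 apart from one change: 2-oxocyclobutyl in place of 2-oxooxetan-3-yl on an amide-type nitrogen. The ring that is exchanged is the only part of the two measured compounds that contains the four-membered ring with an oxygen in it, so the effect of removing that oxygen cannot be read from any measured pair. For the measured compounds named here, with no measured step to lean on, the expectation is that compound 3 moves in the direction of still weaker inhibition, by a step of the size a 10-fold higher number from compound 2 to compound 3 (1.00 log units; beyond the scatter). On that basis, compound 3 is estimated at 60000 nM in this assay, within a range from 10000 nM to 400000 nM.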

Compound 3, half-maximal inhibitory concentration: > 10000000 nM
Compound 3: a limit, no number (the forecaster's own chance of this, stated with the estimate: 40%); at least 160-fold (2.22 log units) between middle value and limit.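

For the compounds shown here, this is the first measured pair that differs in one place, and it isolates the group on the amide-type nitrogen: 2-oxocyclobutyl in place of 2-oxooxetan-3-yl gives an at least 1600-fold higher number from compound 2 to compound 3 (3.22 log units; beyond the scatter). Compound 3 gives no number, only a limit of the assay: the limit of > 10000000 nM in this assay, at which 1 of the 3 values shown sits. Both groups hold 5 heavy atoms, a four-membered non-aromatic ring and 1 double bond outside aromatic rings, so a four-membered ring carrying a carbonyl is not enough on its own at this position, and a change that looks small on paper, a ring carbon for the ring oxygen, separates measurable inhibition from none reaching a number.

This single step cannot separate the loss of the ring oxygen from the drop from 2 hydrogen-bond acceptors to 1 or the loss of the 1 defined stereocentre, as all three change together. The compounds shown also leave open whether a nitrogen in the ring in place of that oxygen would keep any of the inhibition seen with 2-oxooxetan-3-yl.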